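A few compounds are considered here, and "the series" means these few. Any claim that something is new, unique, unknown or untested is made for them only; others in the source may bear on it.

Of the compounds shown here, three with the same nitrocatechol-bearing core have been measured in an assay on isolated protein for inhibition of Amine oxidase [flavin-containing] A (Homo sapiens), read by fluorescence; on this read-out lower numbers stand for stronger inhibition and higher numbers for weaker inhibition. Compound 1 `CC(=O)N1N=C(c2cc(O)c(O)c([N+](=O)[O-])c2)CC1c1ccco1` gives 98000 nM. Compound 2 `CC(=O)N1N=C(c2cc(O)c(O)c([N+](=O)[O-])c2)CC1c1nccs1` gives 84600 nM. Compound 3 `N#Cc1cccc(/C=C/C(=O)c2cc(O)c(O)c([N+](=O)[O-])c2)c1`, in which the five-membered non-aromatic ring is replaced by an open chain, gives 58900 nM. Among these three numbers compound 2 stands second highest, with compound 1 nearest and compound 3 furthest, and both of those gaps lie within the scatter, so no order among the three can be read from them.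

The new compound 4 `CC(=O)N1N=C(c2cc(O)c(O)c([N+](=O)[O-])c2)CC1c1ccc(C#N)cc1` differs from compound 2 in one place: 4-cyanophenyl in place of 1,3-thiazol-2-yl on a saturated ring carbon. Among the measured compounds shown here, the only measured step at this same position is a 1.2-fold lower number from compound 1 to compound 2 (0.06 log units; within the scatter), which swapped one small five-membered aromatic ring for another and changed nothing beyond the scatter. For the measured compounds named here, compound 4 brings a larger six-membered ring with a nitrile, a change no measured pair mirrors, so the expectation rests on that single step and on the narrow spread of the three numbers. Compound 4 is therefore expected to give about 70000 nM, within a range from 25000 nM to 200000 nM, which means an estimated step of a 1.2-fold lower number from compound 2 to compound 4 (0.08 log units; within the scatter), not beyond the scatter.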

Compound 4, half-maximal inhibitory concentration: 76600 nM
Compound 4: the middle estimate sits 1.1-fold (0.04 log units) below what was measured; measured number inside the range.
By their numbers in this assay, from the lowest: compounds 3, 4, 2 and 1 (each within the scatter of the next).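

In this assay, putting 4-cyanophenyl on the saturated ring carbon in place of 1,3-thiazol-2-yl gives a 1.1-fold lower number from compound 2 to compound 4 (0.04 log units; within the scatter) and, set against furan-2-yl, the same group gives a 1.3-fold lower number from compound 1 to compound 4 (0.11 log units; within the scatter) as well. Among the compounds shown here, until now this position had seen only one five-membered aromatic ring exchanged for another; these steps add a six-membered aromatic ring of carbon only, carrying a nitrile, and still nothing moves beyond the scatter. No measurement at hand explains why the number stays so flat.

Going by these compounds, all three groups at this position are aromatic rings, so it remains open whether an amine, a carboxylic acid or a longer chain there would shift the number. A plain phenyl ring would also be needed to tell whether the nitrile contributes anything.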